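Cytotoxicity notes on the ether series, compound 4 pending

This account rests on a few compounds, and the source may have more. Where it says the series, first, only, none or still open, it means among the compounds named here.

Compound 1 `CCC1(Cc2ccccc2)OS(=O)(=O)C=C1OCC#N`: in an ADME assay on HEL cells (Homo sapiens) for cytotoxicity, with a stated time of 3 days (a lower number here means that less compound is tolerated, a higher number that more compound is tolerated), compound 1 gives > 400000 nM, a limit of the assay.
Compound 2 `CCC1(Cc2ccccc2)OS(=O)(=O)C=C1OC`: in this assay compound 2 gives > 400000 nM, again a limit.
Compound 3 `CCC1(Cc2ccccc2)OS(=O)(=O)C=C1OCCCc1ccccc1`: in this assay compound 3 gives >= 20000 nM, also a limit and not a number.

On the numbers shown, compound 3 stands only at a limit, and the two further values shown are limits as well; they sit at the limit of > 400000 nM in this assay, at which 2 of the 3 values shown sit, and at the limit of >= 20000 nM in this assay, at which 1 of the 3 values shown sits. Among the measured compounds shown here, no compound can be ranked against another on these values.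

Compound 4 `CCC1(Cc2ccccc2)OS(=O)(=O)C=C1OCCc1ccccc1` differs from compound 3 by phenyl in place of benzyl on a saturated chain carbon, two bonds along the chain from an oxygen on an unsaturated carbon. The measured steps that might bear on this change are a step that the two limits leave unreadable from compound 1 to compound 2, a step that the two limits leave unreadable from compound 1 to compound 3 and a step that the two limits leave unreadable from compound 2 to compound 3. None of them has a readable size, since each end of each step is a limit. For the measured compounds named here, there is therefore no measured step of known size to project onto the change from compound 3 to compound 4, and the expectation rests on the fact that every value so far is a limit.

The step is therefore expected to be a step that the limit leaves unreadable from compound 3 to compound 4, nothing beyond the scatter. For compound 4 the estimate in this assay is 100000 nM, expected to fall between 20000 nM and 400000 nM, and most probably reported as a limit rather than a number.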

Compound 4, minimum cytotoxic concentration: >= 20000 nM
Compound 4: no number, only a limit; the forecaster's own chance of this, stated with the estimate: 70%; the middle value is on the limit's open side.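

Compound 4 returns only a limit, so no step from compound 1, compound 2 or compound 3 to compound 4 can be read, and all four values remain limits: the limit of >= 20000 nM in this assay, at which 2 of the 4 values shown sit.

The compounds shown leave open where compound 1, compound 2, compound 3 and compound 4 would give an actual number in this assay, and so how the ether chain bears on it.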